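The source may hold more compounds than are shown below. What is called first, only, known or untested is meant among the compounds shown, and "the series" means these compounds.

Measured in an ADME assay on RAW264.7 cells (Mus musculus) for cytotoxicity, read by MTT assay, with a stated time of 48 h; on this read-out lower numbers stand for higher toxicity in this test and higher numbers for lower toxicity in this test:
compound 1 `S=C(N/N=C\c1ccnc2ccccc12)Nc1cccnc1`: 91600 nM
compound 2 `CCc1ccc(NC(=S)N/N=C\c2ccnc3ccccc23)cc1`: 35700 nM
compound 3 `Fc1ccc(NC(=S)N/N=C\c2ccnc3ccccc23)cc1`: 45900 nM

Compound 3 sits within the scatter of both other compounds, with a 1.3-fold higher number from compound 2 to compound 3 (0.11 log units; within the scatter) and a 2.0-fold lower number from compound 1 to compound 3 (0.30 log units; within the scatter). Within the data shown here, only one pair stands clearly apart, with a 2.6-fold lower number from compound 1 to compound 2 (0.41 log units; beyond the scatter), and that step is modest.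

The next compound is compound 4 `S=C(N/N=C\c1ccnc2ccccc12)Nc1ccccc1`. It differs from compound 3 in one place: hydrogen in place of fluoro on an aromatic carbon. In words, hydrogen replaces fluoro on an aromatic carbon, turning 4-fluorophenyl into phenyl.

The closest guide is the exchange of ethyl for fluoro on an aromatic carbon, where a 1.3-fold higher number from compound 2 to compound 3 (0.11 log units; within the scatter) stayed within the scatter. The steps away from pyridin-3-yl concern a different change and were small as well. No step beyond the scatter is therefore expected in this assay, and no direction can be favoured with confidence.

The expected change is a 1.1-fold higher number from compound 3 to compound 4 (0.04 log units; within the scatter).

The estimate for compound 4 is 50000 nM, with an expected range of 25000 nM to 95000 nM.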

Compound 4, half-maximal cytotoxic concentration: 118000 nM
Compound 4: the middle estimate sits 2.4-fold (0.37 log units) below what was measured; measured number above the stated range.
By their numbers in this assay, from the lowest: compounds 2, 3, 1 and 4 (each within the scatter of the next, the first and the last beyond it).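

In this assay the position para to a large group turns out to matter: hydrogen in place of fluoro gives a 2.6-fold higher number from compound 3 to compound 4 (0.41 log units; beyond the scatter) and hydrogen in place of ethyl gives a 3.3-fold higher number from compound 2 to compound 4 (0.52 log units; beyond the scatter) while those two substituted rings stay within the scatter of each other. Each of the two groups thus goes with a lower number, meaning higher toxicity in this test, than plain phenyl does. Phenyl in place of pyridin-3-yl gives only a 1.3-fold higher number from compound 1 to compound 4 (0.11 log units; within the scatter) so that ring change alone does not separate these two compounds, and no measurement at hand explains any of this.

As far as these compounds go, whether a methoxy group or an amine at this place would behave like fluoro and ethyl or like hydrogen stays open. So does whether adding fluoro to the pyridin-3-yl ring would bring a similar step.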